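A few compounds are considered here, and "the series" means these few. Any claim that something is new, unique, unknown or untested is made for them only; others in the source may bear on it.

Compound 1 `CCCOc1ccc(-c2cn3c(=O)n(-c4ccccc4)nc3c(N)n2)cc1` was tested in an assay on cells for displacement of a labelled ligand from adenosine receptor A3 (Homo sapiens), read by scintillation counting, with a stated time of 3 h; a higher number here means a weaker inhibitor, a lower number a stronger inhibitor. In this assay compound 1 gives only a limit of the assay, > 30000 nM, so no exact number is known for it (the limit of > 30000 nM in this assay, at which 1 of the 2 values shown sits). Compound 2 `O=c1[nH]c(-c2ccc(O)cc2)cn2c(=O)n(-c3ccccc3)nc12`, with the same core, gives 207 nM in this assay. Compound 3 `CC(C)Oc1ccc(-c2cn3c(=O)n(-c4ccccc4)nc3c(N)n2)cc1` differs from compound 1 by one change: isopropyl in place of propyl on an oxygen on an aromatic ring. Within the data shown here, no measured pair shows what this change does, so the step is expected to stay within the usual scatter, a number no higher from compound 1 to compound 3 (the limit leaves the size open), and this assay will probably again report only a limit. Compound 3 is therefore expected to give 30000 nM, within 5000 nM to 100000 nM.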

Compound 3, inhibition constant: > 30000 nM
Compound 3 was reported as a limit; the forecaster's own chance of this, stated with the estimate: 70%; the middle value sits exactly at the limit.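

In this assay, among these compounds, compound 3, like compound 1, is reported only as a limit, so no step between the two can be read. The compounds shown leave open whether isopropyl in place of propyl changes the inhibition constant at all.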